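The source may hold more compounds than are shown below. What is called first, only, known or untested is meant among the compounds shown, and "the series" means these compounds.

Measured so far in an ADME assay on L02 cells (Homo sapiens) for inhibition, read by MTT assay, with a stated time of 48 h, tested at 100 uM; a lower number here means a weaker effect, a higher number a stronger effect of the compound at the concentration tested:
- compound 1 `O=C(Nc1cccc(Cl)c1)Nc1ccc(-c2cc(=O)c3ccccc3o2)c(Cl)c1`: 47.1%
- compound 2 `CCc1ccc2oc(-c3ccc(NC(=O)Nc4cccc(Cl)c4)cc3Cl)cc(=O)c2c1`: 37.2%

Going by the values given here, compound 2 gives the lowest of the two numbers; the nearest is compound 1, and the one step between them, a number 9.9 percentage points lower from compound 1 to compound 2 (within the scatter), lies within the scatter, so the two values cannot be ordered.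

Compound 3 `COc1ccc2oc(-c3ccc(NC(=O)Nc4cccc(Cl)c4)cc3Cl)cc(=O)c2c1` is not yet measured. It differs from compound 2 in one place: methoxy in place of ethyl on an aromatic carbon. Among the compounds with values here, no measured step compares methoxy with ethyl at this position. Within the data shown here, the only step touching this carbon, a number 9.9 percentage points lower from compound 1 to compound 2 (within the scatter), shows that putting an ethyl there in place of hydrogen left the read-out within the scatter. On that basis no step beyond the scatter is expected from compound 2 to compound 3, estimated as a number 2.8 percentage points higher from compound 2 to compound 3 (within the scatter). Compound 3 is therefore expected to give about 40% in this assay, with a range from 25% to 55%.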

Compound 3, a percentage reported as inhibition, at one concentration (the size of the read-out at that concentration, not a potency): 40.6%
Estimate against measurement, compound 3: 0.6 percentage points below; low and high end bracket the measured number.
By their numbers in this assay, from the lowest: compounds 2, 3 and 1 (each within the scatter of the next).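

In this assay, the exchange of ethyl for methoxy on this aromatic carbon, which brings in an oxygen and a hydrogen-bond acceptor, gives a number 3.4 percentage points higher from compound 2 to compound 3 (within the scatter) and thus adds a second substituent comparison at this position. Methoxy in place of hydrogen gives a number 6.5 percentage points lower from compound 1 to compound 3 (within the scatter) and so, like ethyl, does not separate from hydrogen in this read-out at the single concentration tested, while the two groups also cannot be told apart from each other. No measurement available here explains the read-out at this position.

Going by these compounds, it remains open whether an amine, a carboxylic acid or a longer chain such as butyl on this carbon would shift the read-out beyond the scatter. Also open, on these data alone, is whether methoxy or ethyl on another carbon of this ring would behave in the same way.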